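The source may hold more compounds than are shown below. What is called first, only, known or untested is meant among the compounds shown, and "the series" means these compounds.

Measured so far in a functional assay on the whole organism (artery, strain albino) with Rattus norvegicus as the target, with a stated time of 240 min, at a dose of 10 mg/kg by the oral route; a higher number here means more inhibition at the dose given (going by the name of the read-out), a lower number less inhibition:

Compound 1 `CC1=C(C(=O)Nc2ccc(F)cc2)C(c2ccc([N+](=O)[O-])cc2)N=C(SCc2ccc(Cl)cc2)N1` gives 33.3%.
Compound 2 `CC1=C(C(=O)Nc2ccc(F)cc2)C(c2ccc([N+](=O)[O-])cc2)N=C(SCc2ccc(F)cc2)N1` gives 25.6%.
Compound 3 `CC1=C(C(=O)Nc2ccc([N+](=O)[O-])cc2)C(c2cccc([N+](=O)[O-])c2)N=C(SCc2ccc(Cl)cc2)N1` gives 20%.

Compound 1 and compound 2 share one core and differ in a single place: fluoro in place of chloro on an aromatic carbon. That change produced a number 7.7 percentage points lower from compound 1 to compound 2 (within the scatter), a shift too small to count as a real difference between the two compounds. Compound 3 is built on a different core carrying two nitro groups, and how its core differs from that of compound 1 is not broken down here. Its reading lies close to that of compound 2, while the gap to compound 1 is large enough to stand out.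

Compound 4 `CC1=C(C(=O)Nc2ccc([N+](=O)[O-])cc2)C(c2cccc([N+](=O)[O-])c2)N=C(SCc2ccc(F)cc2)N1` has not yet been measured. It differs from compound 3 by fluoro in place of chloro on an aromatic carbon, the very same change, at the same place, that leads from compound 1 to compound 2. Within the data shown here, that earlier pair is the only guide. The step from compound 3 to compound 4 is therefore expected to be a number 5 percentage points lower from compound 3 to compound 4 (within the scatter) because the earlier pair gave a number 7.7 percentage points lower from compound 1 to compound 2 (within the scatter). In this assay compound 4 is expected to give about 15%, most likely between 5% and 27%.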

Compound 4, a percentage reported as inhibition, in the whole organism at one dose (the size of the read-out at that dose, not a potency): 22.6%
The estimate for compound 4 lay 7.6 percentage points below the measured number, within the range that was stated.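

On the core of compound 3, fluoro in place of chloro on the benzyl group gave a number 2.6 percentage points higher from compound 3 to compound 4 (within the scatter) in this assay, so here too the swap stays inside the usual spread of repeated measurements. Set beside the same swap on the core of compound 1, the two steps cannot be told apart: the same change on two cores in this assay, a number 7.7 percentage points lower (within the scatter) from compound 1 to compound 2 and a number 2.6 percentage points higher (within the scatter) from compound 3 to compound 4, 10.3 percentage points apart, within the scatter of two such steps. This fits a change that stays small on both cores, but two pairs with steps this small show neither a fixed size nor a fixed direction for it, and they do not show that chloro and fluoro truly differ in this assay.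

The compounds shown carry only chloro or fluoro at this place on the benzyl ring, so the effect of a larger change there, such as a methoxy group, a nitrile or a carboxylic acid, remains open. Also open, from the compounds shown here alone, is whether a longer chain in place of the benzyl group would shift the reading beyond the scatter.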